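A few compounds are considered here, and "the series" means these few. Any claim that something is new, unique, unknown or untested is made for them only; others in the source may bear on it.

Two compounds of the series carry a number for solubility. In a physicochemical assay for solubility, with a stated time of 18 h, at pH 7.4 (on this read-out lower numbers stand for lower solubility and higher numbers for higher solubility), compound 1 `COc1ccc(-c2ccc3c(NCCCNCc4cccc(OC)c4O)ccnc3c2)cc1` gives 32000 nM, and compound 2 `COc1ccc(F)cc1CNCCCNc1ccnc2cc(Cc3ccccc3)ccc12` gives 4200 nM. Compound 2 stands at the lower of the two numbers; compound 1 is its nearest neighbour and lies beyond the scatter from it. Compound 3 `COc1ccc(-c2ccc3c(NCCCNCc4cc(F)ccc4OC)ccnc3c2)cc1` has not yet been measured in this assay. It differs from compound 2 in one place: 4-methoxyphenyl in place of benzyl on an aromatic carbon. Going by the values given here, no pair of measured compounds that differ in one place is available, so the size of this step cannot be read from a known pair. Compound 3 shares the 4-methoxyphenyl with compound 1, whose value in this assay is 32000 nM. An upward step is expected, a 1.9-fold higher number from compound 2 to compound 3 (0.28 log units; within the scatter), although compound 1 and compound 2 also differ elsewhere, which leaves the size uncertain. For compound 3 the estimate is 8000 nM, with a range from 1500 nM to 32000 nM.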

Compound 3, solubility: 32000 nM
Compound 3: middle estimate off by 4.0-fold (0.60 log units), on the low side, within the range that was stated.
By their numbers in this assay, from the lowest: compound 2; then compounds 1 and 3 (each within the scatter of the next).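

In this assay, the aromatic carbon now has a measured step: 4-methoxyphenyl in place of benzyl gives a 7.6-fold higher number from compound 2 to compound 3 (0.88 log units; beyond the scatter) with 5-fluoro-2-methoxyphenyl held on the chain. On the saturated chain carbon bound to an amine nitrogen, 5-fluoro-2-methoxyphenyl in place of 2-hydroxy-3-methoxyphenyl gives no change at the digits printed from compound 1 to compound 3 (within the scatter) with 4-methoxyphenyl held on the aromatic carbon, so this exchange does not register on the read-out in that setting. Nothing available bears on what lies behind either step.

The pair of compounds 2 and 3 does not separate the methoxy group from the change of benzyl to a directly attached aryl ring, which a plain phenyl at that carbon would address. Also open, from the compounds shown here alone, is how an amine or a carboxylic acid on that aromatic carbon would read here.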